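The source may hold more compounds than are shown below. What is called first, only, known or untested is meant among the compounds shown, and "the series" means these compounds.

Going by the values given here, only one number exists so far in this small series. In a functional assay on the whole organism (strain albino) with Mus musculus as the target, with a stated time of 0.5 h (a higher number here means that more compound is needed for the effect, a lower number that less compound is needed), compound 1 `CC(=O)N1N=C(Nc2nc3ccc(C)cc3s2)CC1c1ccc(O)cc1` gives 54.3 umol/kg as its dose for half-maximal effect. Compound 2 `Cc1ccc2nc(NC(=O)/C=C/c3ccc(O)cc3)sc2c1` carries the entry "not determined" (no result reported) in the same test, and compound 3 `CC(=O)N1N=C(Nc2nc3ccc([N+](=O)[O-])cc3s2)CC1c1ccc(O)cc1` carries the entry "not determined" (no result reported) there as well. Compound 3 therefore has no place on the numerical scale: it cannot be ranked against compound 1, and compound 2 offers no comparison either.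

Compound 4 `CC(=O)N1N=C(Nc2nc3ccc([N+](=O)[O-])cc3s2)CC1c1ccc(Cl)cc1` differs from compound 3 in one place, counted as chloro in place of hydroxy on an aromatic carbon and amounting to chloro in place of hydroxy on an aromatic carbon, para to a large group, so that 4-hydroxyphenyl gives way to 4-chlorophenyl.

Among the compounds with values here, no measured pair shows what such a change does, and compound 3 supplies no starting value, so the step in this assay cannot be read from data. A shift beyond the usual scatter is not expected in either direction. Within the data shown here, the sole anchor is compound 1 at 54.3 umol/kg of measured dose, and the estimate stays wide. For compound 4 the expected dose is 55 umol/kg within an estimated range from 15 umol/kg to 190 umol/kg in this test series.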

Compound 4, dose for half-maximal effect: 138 umol/kg
For compound 4 the middle estimate is 2.5-fold (0.40 log units) below the measured one, within the range that was stated.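

No step can be read from compound 3 to compound 4: compound 4 gives 138 umol/kg in this assay, while compound 3 has no single number there. The compounds shown leave open what chloro in place of hydroxy does to the dose for half-maximal effect. No supporting data bear on this result.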